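The source may report more compounds than this note shows. Statements on the series, on what has been measured and on what is new or still open speak of the compounds shown alone.

Compound 1 `Cc1ccccc1Cc1ccc(N2CCC[C@H]2CC(=O)O)cc1` carries no substituent on the saturated carbons of its five-membered ring. In an assay on HEK293 cells for binding affinity to Free fatty acid receptor 1 (Homo sapiens), read by scintillation counting and radioligand binding, with a stated time of 1 h (a lower number here means a stronger inhibitor, a higher number a weaker inhibitor), compound 1 gives 1300 nM, the highest of the two numbers at hand. For the measured compounds named here, its only measured neighbour is compound 2 `Cc1ccccc1Cc1ccc(N2CC[C@H](C)[C@H]2CC(=O)O)cc1`, which in this assay gives 310 nM; the step of a 4.2-fold lower number from compound 1 to compound 2 (0.62 log units; beyond the scatter) is a methyl in place of hydrogen on a saturated ring carbon.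

Compound 3 `Cc1ccccc1Cc1ccc(N2C[C@@H](C)C[C@H]2CC(=O)O)cc1` has not yet been measured. It differs from compound 1 by methyl in place of hydrogen on a saturated ring carbon: two ring bonds from the ring nitrogen, two ring bonds from the ring atom that bears the carboxymethyl group, and two ring bonds from the ring atom that bears the large group. Going by the values given here, the one step that bears on this change is a 4.2-fold lower number from compound 1 to compound 2 (0.62 log units; beyond the scatter), but that methyl sits on a different saturated ring carbon, so its size cannot be carried over directly. A methyl on this ring has so far given a lower number, and a smaller gain of that kind is expected here: the step from compound 1 to compound 3 is estimated at a 1.6-fold lower number from compound 1 to compound 3 (0.21 log units; within the scatter). In this assay compound 3 is therefore expected to give about 800 nM, within a range of 300 nM to 2000 nM.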

Compound 3, inhibition constant: 360 nM
Beside the measured number, compound 3's estimate is 2.2-fold (0.35 log units) above it, and the stated range covers the measured number.
By their numbers in this assay, from the lowest: compounds 2 and 3 (each within the scatter of the next); then compound 1.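

In this assay, the methyl at the saturated ring carbon two ring bonds from the ring nitrogen gives a step of a 3.6-fold lower number from compound 1 to compound 3 (0.56 log units; beyond the scatter), which shows that the lower number seen in the step of a 4.2-fold lower number from compound 1 to compound 2 (0.62 log units; beyond the scatter) is not confined to a single saturated ring carbon. Compound 2 gives 310 nM and compound 3 gives 360 nM, values within the scatter of each other, so this assay does not separate the two placements of the methyl on the ring. The data offer no explanation for the effect of the methyl at either carbon.

The compounds shown leave open whether an ethyl, a hydroxyl or a fluorine at this same carbon would give a step like that of the methyl, and whether the methyl would do the same in the opposite stereochemical arrangement. They also leave open whether methyl groups on both saturated ring carbons together would lower the number further than either one alone.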